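Piperidin-1-yl in place of the ethoxycarbonyl piperazine

A few compounds are considered here, and "the series" means these few. Any claim that something is new, unique, unknown or untested is made for them only; others in the source may bear on it.

In a functional assay on MIA PaCa-2 cells (Homo sapiens) for inhibition, read by MTT assay, with a stated time of 48 h, tested at 10 uM (a higher number here means more inhibition of growth at the concentration tested, a lower number less inhibition of growth), compound 3 `CCOC(=O)N1CCN(Cc2c(O)c([C@H]3CCN(C)C[C@H]3O)c3oc(C)cc(=O)c3c2O)CC1` gives 4%. On the same scale compound 2 `Cc1cc(=O)c2c(O)c(CN3CCCC3CO)c(O)c([C@H]3CCN(C)C[C@H]3O)c2o1` gives 13% and compound 1 `Cc1cc(=O)c2c(O)c(CN3CCC(N4CCCCC4)CC3)c(O)c([C@H]3CCN(C)C[C@H]3O)c2o1` gives 23%. Compound 3 stands within the scatter of compound 2, and its gap to compound 1 lies beyond the scatter. Compound 4 `Cc1cc(=O)c2c(O)c(CN3CCCCC3)c(O)c([C@H]3CCN(C)C[C@H]3O)c2o1` has piperidin-1-yl in place of 4-(ethoxycarbonyl)piperazin-1-yl on a saturated chain carbon bound to an aromatic carbon. Going by the values given here, the only measured step at this place is a number 9 percentage points lower from compound 2 to compound 3 (within the scatter) and it concerns a different replacement, so it offers weak guidance. A small rise in this assay is expected, not clearly beyond the scatter, with the expected step being a number 9 percentage points higher from compound 3 to compound 4 (within the scatter) as a working figure. For compound 4 the estimated value is 13% with an expected range of 3% to 28% for now.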

Compound 4, percent growth inhibition at one concentration: 14%
For compound 4 the middle estimate is 1 percentage points below the measured one; the range from low to high includes it.
By their numbers in this assay, from the lowest: compounds 3, 2, 4 and 1 (each within the scatter of the next, the first and the last beyond it).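

In this assay piperidin-1-yl on a saturated chain carbon bound to an aromatic carbon gives a number 10 percentage points higher from compound 3 to compound 4 (within the scatter) and a number 1 percentage points higher from compound 2 to compound 4 (within the scatter) and so separates clearly from neither neighbouring group. Hydrogen in place of piperidin-1-yl on a saturated ring carbon gives a number 9 percentage points lower from compound 1 to compound 4 (within the scatter) and thus does not show that this outer ring matters on its own. Nothing at hand explains these steps. Still open, as far as these compounds go, is how a carboxylic acid or a dimethylamino group on the same chain carbon would read in this assay at this single concentration.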